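From Methoxy to Trifluoromethoxy: an Expected Cytotoxicity Value

The source may report more compounds than this note shows. Statements on the series, on what has been measured and on what is new or still open speak of the compounds shown alone.

Compound 1, `COc1ccc(C(=O)c2cc(OC)c(OC)c(OC)c2)cc1N`: 1100 nM
Compound 2, `COc1cccc(/C=C/C(=O)Nc2cc(OC)c(OC)c(OC)c2)c1`: 2100 nM
Compound 3, `COc1cccc(/C=C/C(=O)Nc2cc(C(=O)c3cc(OC)c(OC)c(OC)c3)ccc2OC)c1`: 4700 nM

All three measured compounds were tested in a functional assay on PC-3 cells (Homo sapiens) for cytotoxicity, read by MTT assay, with a stated time of 72 h; on this read-out higher numbers stand for weaker inhibition and lower numbers for stronger inhibition. Among them compound 3 stands at the highest number of the three, meaning the weakest inhibition recorded here. Its nearest neighbour is compound 2, whose number is lower by a margin that lies beyond the scatter of repeated measurements, and compound 1 lies further below still, again beyond the scatter. Compound 3 is therefore the weakest of the three on this read-out.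

Compound 4, `COc1ccc(C(=O)c2cc(OC)c(OC)c(OC)c2)cc1NC(=O)/C=C/c1cccc(OC(F)(F)F)c1`, has not yet been measured. It differs from compound 3 in a single place: trifluoromethyl in place of methyl on an oxygen on an aromatic ring. Among the measured compounds shown here, no measured pair in this set carries the same exchange, so there is no step on record to give the size or direction of its effect. With nothing to lean on, the reasonable expectation is a step of no size beyond the scatter, and the step is estimated as a 1.2-fold lower number from compound 3 to compound 4 (0.07 log units; within the scatter). On that basis compound 4 is expected to give about 4000 nM, with a range from 1500 nM to 11000 nM.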

Compound 4, half-maximal inhibitory concentration: 7700 nM
Estimate against measurement, compound 4: 1.9-fold (0.28 log units) below, and the stated range covers the measured number.
By their numbers in this assay, from the lowest: compounds 1 and 2 (each within the scatter of the next); then compounds 3 and 4 (each within the scatter of the next).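

In this assay, the exchange of methoxy for trifluoromethoxy gives a 1.6-fold higher number from compound 3 to compound 4 (0.21 log units; within the scatter), so this read-out does not separate the 3-methoxyphenyl group from the 3-(trifluoromethoxy)phenyl group. Among the compounds shown here, the earlier compounds offered no pair differing in one place, and this is the first single step on record: on an oxygen on an aromatic ring, trifluoromethyl can stand in place of methyl, with three fluorine atoms added, without a shift beyond the scatter. No measurement on hand speaks to what lies behind this outcome.

What the compounds shown leave open is whether this place is as undemanding for other groups, since a single exchange cannot say how a hydroxyl, an ethoxy or an amine would read in this assay. As far as these compounds go, it also remains open whether the same exchange from methoxy to trifluoromethoxy would stay within the scatter on another compound, because this one pair is the only case on record and a single step cannot establish a general pattern.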